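Hydroxyl for chlorine on the pendant aryl of compound 3

The compounds below may be only part of what the source reports. "The series", "measured", "known", "first", "only" and "open" are said of these compounds alone.

Three compounds share one core and differ only in the aryl group carried on an aromatic carbon of the fused ring system. Compound 1 `COc1ccc(-c2ccc3ncn(-c4cc(OC)c(OC)c(OC)c4)c3c2)cc1O` gives 44 nM in a functional assay on SGC-7901 cells (Homo sapiens) for antiproliferative activity, read by MTT assay, with a stated time of 72 h; a higher number here means a weaker inhibitor, a lower number a stronger inhibitor. Compound 2 `COc1cc(-n2cnc3ccc(-c4ccccc4)cc32)cc(OC)c1OC` gives 290 nM, and compound 3 `COc1cc(-n2cnc3ccc(-c4cccc(Cl)c4)cc32)cc(OC)c1OC` gives 1490 nM, the highest of the three numbers. The step of a 6.6-fold higher number from compound 1 to compound 2 (0.82 log units; beyond the scatter) is modest, the step of a 5.1-fold higher number from compound 2 to compound 3 (0.71 log units; beyond the scatter) is likewise modest, and together they make the large step of a 34-fold higher number from compound 1 to compound 3 (1.53 log units; beyond the scatter).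

Compound 4 `COc1cc(-n2cnc3ccc(-c4ccc(O)cc4)cc32)cc(OC)c1OC` has not been measured. It differs from compound 3 by 4-hydroxyphenyl in place of 3-chlorophenyl on an aromatic carbon. Among the compounds with values here, two measured steps bear on this. Reversing the chloro for hydrogen change of compound 2 to compound 3 accounts for a step about as large as a 5.1-fold higher number from compound 2 to compound 3 (0.71 log units; beyond the scatter), and the hydroxyl entering here recalls the hydroxy-bearing aryl of compound 1, whose step a 6.6-fold higher number from compound 1 to compound 2 (0.82 log units; beyond the scatter) points the same way. The step of an 11-fold lower number from compound 3 to compound 4 (1.06 log units; beyond the scatter) is therefore expected to be downward and beyond the scatter. For compound 4 the estimate in this assay is 130 nM, with a range from 40 nM to 450 nM.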

Compound 4, half-maximal inhibitory concentration: > 10000 nM
Compound 4 was reported as a limit; the forecaster's own chance of this, stated with the estimate: 2%; middle value at least 76-fold (1.88 log units) from the limit.
By their numbers in this assay, from the lowest: compound 1; then compound 2; then compound 3. At a limit, above all of these: compound 4.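

In this assay compound 4 is reported only as a limit: the limit of > 10000 nM in this assay, at which 1 of the 4 values shown sits.

Hydroxy in place of hydrogen on the pendant aryl gives an at least 34-fold higher number from compound 2 to compound 4 (1.53 log units; beyond the scatter) and 4-hydroxyphenyl in place of 3-hydroxy-4-methoxyphenyl gives an at least 220-fold higher number from compound 1 to compound 4 (2.35 log units; beyond the scatter) so a hydroxyl on this aryl does not by itself go with the low number of compound 1. 4-Hydroxyphenyl in place of 3-chlorophenyl gives an at least 6.7-fold higher number from compound 3 to compound 4 (0.82 log units; beyond the scatter) and so the chloro compound, the highest of the earlier numbers, no longer marks the weak end at this position.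

The compounds shown leave open whether the hydroxyl of compound 1 depends on the methoxy group on the same ring. They also leave open how an amine or a carboxylic acid in place of the hydroxyl of compound 4 would compare.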